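A few compounds are considered here, and "the series" means these few. Any claim that something is new, unique, unknown or untested is made for them only; others in the source may bear on it.

Compound 1 `CCCCCCCC/C=C\CCCCCCCC(=O)N1CCCC1`: 0.2 ug/mL
Compound 2 `CCCCC/C=C\C/C=C\CCCCCCCC(=O)N1CCCCC1`: 63.2 ug/mL

In a functional assay on NCI/ADR-RES cells (Homo sapiens) for antiproliferative activity, read by sulforhodamine B assay, with a stated time of 48 h (a higher number here means a weaker inhibitor of growth, a lower number a stronger inhibitor of growth), compound 2 stands highest of the two at 63.2 ug/mL, and compound 1 gives 0.2 ug/mL. The gap between these two values lies beyond the scatter. Compound 3 `CCCCCCCC/C=C\CCCCCCCC(=O)N1CCCCC1` differs from compound 2 by one change: heptyl in place of hept-1-en-1-yl on a saturated chain carbon bound to a double-bonded chain carbon. For the measured compounds named here, no measured step shows the effect of this change. Going by the values given here, with compound 1 at 0.2 ug/mL as the only lower value, a fall beyond the scatter is expected, and the estimated step is an 11-fold lower number from compound 2 to compound 3 (1.02 log units; beyond the scatter). For compound 3 the estimated value is 6 ug/mL, with an expected range of 0.6 ug/mL to 40 ug/mL.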

Compound 3, concentration for 50% growth inhibition: 7.7 ug/mL
Compound 3: middle estimate off by 1.3-fold (0.11 log units), on the low side, within the range that was stated.
By their numbers in this assay, from the lowest: compound 1; then compound 3; then compound 2.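

In this assay the two parts of the molecule can now be read separately. With the amine part held as piperidin-1-yl, heptyl in place of hept-1-en-1-yl gives an 8.2-fold lower number from compound 2 to compound 3 (0.91 log units; beyond the scatter) and with the chain held, piperidin-1-yl in place of pyrrolidin-1-yl on a carbonyl carbon gives a 39-fold higher number from compound 1 to compound 3 (1.59 log units; beyond the scatter) so each change alone moves growth inhibition. Nothing available explains either step.

On these data alone, whether the ring step holds on the chain of compound 2 remains open. So does the effect of azepan-1-yl or morpholin-4-yl on the carbonyl carbon.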